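The source may report more compounds than this note shows. Statements on the series, on what has been measured and on what is new or still open speak of the compounds shown alone.

Compound 1 `COc1ccc(/C=C2\COC/C(=C\c3ccccc3F)C2=O)cc1O`: 13800 nM
Compound 2 `O=C1/C(=C/c2ccccc2)COC/C1=C\c1ccccc1F`: 17600 nM

Both compounds were tested in a functional assay on A549 cells (Homo sapiens) for cytotoxicity, read by MTT assay, with a stated time of 72 h (a lower number here means a stronger inhibitor, a higher number a weaker inhibitor), and compound 2 stands within the scatter of compound 1, so the two numbers cannot be told apart. Compound 3 `O=C1/C(=C/c2cccc(O)c2)COC/C1=C\c1ccccc1F` follows from compound 2 by one change, hydroxy in place of hydrogen on an aromatic carbon, which turns phenyl into 3-hydroxyphenyl. Among the compounds with values here, no measured pair shows what this change does, so no step beyond the scatter is expected in this assay, in either direction. The expected 1.4-fold lower number from compound 2 to compound 3 (0.13 log units; within the scatter) therefore stays small. For compound 3 the estimated value is 13000 nM, with an expected range of 5500 nM to 30000 nM.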

Compound 3, half-maximal inhibitory concentration: 7400 nM
Estimate against measurement, compound 3: 1.8-fold (0.24 log units) above, and the stated range covers the measured number.
By their numbers in this assay, from the lowest: compounds 3, 1 and 2 (each within the scatter of the next, the first and the last beyond it).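

In this assay, within the data shown here, hydroxy in place of hydrogen on the aromatic carbon, turning phenyl into 3-hydroxyphenyl, gives a 2.4-fold lower number from compound 2 to compound 3 (0.38 log units; beyond the scatter) in a first step beyond the scatter, though a modest one. With that hydroxy group in place, hydrogen in place of methoxy gives a 1.9-fold lower number from compound 1 to compound 3 (0.27 log units; within the scatter) and so cannot be told apart from no change. Nothing measured here bears on the reason for either step. The compounds shown leave open whether an amine or a carboxylic acid on the same aromatic carbon would give a similar step, and whether the hydroxy step would hold on the fluorophenyl ring.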